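This account rests on a few compounds, and the source may have more. Where it says the series, first, only, none or still open, it means among the compounds named here.

Working notes on the series. In a functional assay with Oryctolagus cuniculus as the target (a lower number here means a stronger inhibitor, a higher number a weaker inhibitor), compound 1 (`Nc1noc2ccc(-n3nc(C(F)(F)F)c4c3C(=O)N(c3ccc(-c5ccccc5CN5CCCC5)cc3F)CC4)cc12`) gives 1000 nM and compound 2 (`CN(C)Cc1ccccc1-c1ccc(N2CCc3c(C(F)(F)F)nn(-c4ccc5onc(N)c5c4)c3C2=O)c(F)c1`) gives 600 nM. Among the measured compounds shown here, these are the only two numbers so far, and they lie within the scatter of each other, so compound 2 holds no clear place ahead of compound 1.

Compound 3 (`Nc1noc2ccc(-n3nc(C(F)(F)F)c4c3C(=O)N(c3ccc(-c5ccccc5CN5CC[C@@H](O)C5)cc3F)CC4)cc12`) differs from compound 2 on a saturated chain carbon bound to an aromatic carbon: 3-hydroxypyrrolidin-1-yl in place of dimethylamino on a saturated chain carbon bound to an aromatic carbon. For the measured compounds named here, one measured step bears on this place: a 1.7-fold lower number from compound 1 to compound 2 (0.22 log units; within the scatter), an exchange of pyrrolidin-1-yl for dimethylamino that stays within the scatter. Going by the values given here, no measured compound carries 3-hydroxypyrrolidin-1-yl, so the data do not show what it contributes.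

No step beyond the scatter is therefore expected in this assay, and the expected step is a 1.3-fold higher number from compound 2 to compound 3 (0.12 log units; within the scatter). For compound 3 the estimated value is 800 nM, with an expected range of 300 nM to 2200 nM.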

Compound 3, half-maximal inhibitory concentration: 600 nM
Compound 3: the middle estimate sits 1.3-fold (0.12 log units) above what was measured; the measured number falls inside the stated range.
By their numbers in this assay, from the lowest: compounds 2, 3 and 1 (each within the scatter of the next).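

At this place, on a saturated chain carbon bound to an aromatic carbon, the exchange of dimethylamino for 3-hydroxypyrrolidin-1-yl brings in a ring, a hydroxy group and a defined stereocentre, yet this assay shows no step beyond the scatter (no change at the digits printed from compound 2 to compound 3 (within the scatter)). The hydroxy group, read on its own as hydroxy in place of hydrogen on a saturated ring carbon, also stays within the scatter (a 1.7-fold lower number from compound 1 to compound 3 (0.22 log units; within the scatter)). No evidence in hand bears on why these steps stay so small.

Open, on these data alone, is whether the opposite configuration of the hydroxy-bearing carbon, a morpholine ring or a carboxylic acid at this place would give a step beyond the scatter in this assay. Also open, as far as these compounds go, is whether a primary amine here would do so.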